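Urea diaryl ether series: expectation for compound 3

The source may report more compounds than this note shows. Statements on the series, on what has been measured and on what is new or still open speak of the compounds shown alone.

Measured compounds:
compound 1, `Cn1ncnc1-c1cc(Oc2ccc(NC(=O)Nc3cccc(C(F)(F)F)c3)cc2F)ccn1`, 9680 nM
compound 2, `CN(C)CCn1cnnc1-c1cc(Oc2ccc(NC(=O)Nc3cccc(C(F)(F)F)c3)cc2F)ccn1`, 16400 nM

Both numbers come from a functional assay on MDA-MB-231 cells (Homo sapiens) for antiproliferative activity, read by MTT assay, with a stated time of 72 h; on this read-out lower numbers stand for stronger inhibition and higher numbers for weaker inhibition. Among the measured compounds shown here, compound 2 stands at the higher of the two numbers; its only neighbour is compound 1, and the step of a 1.7-fold higher number from compound 1 to compound 2 (0.23 log units; within the scatter) lies within the scatter, so the two compounds cannot be put in order on this read-out.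

Compound 3, `CN(C)CCn1cnnc1-c1cc(Oc2ccc(NC(=O)Nc3ccc(F)c(Cl)c3)cc2F)ccn1`, differs from compound 2 in one place: 3-chloro-4-fluorophenyl in place of 3-(trifluoromethyl)phenyl on an amide-type nitrogen. For the measured compounds named here, the single measured step, a 1.7-fold higher number from compound 1 to compound 2 (0.23 log units; within the scatter), concerns the substituent on the shared core and not the aryl group on the urea nitrogen, so no measured pair bears on the change from compound 2 to compound 3. Going by the values given here, with no comparable step available, the expectation rests on compound 2 alone: the number for compound 3 in this assay is expected to stay near that of compound 2, without a step beyond the scatter, the estimated step being a 1.1-fold lower number from compound 2 to compound 3 (0.04 log units; within the scatter). The wide range reflects the absence of any measured aryl replacement in the series.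

For compound 3 the estimate in this assay is 15000 nM, with a range from 4000 nM to 50000 nM.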

Compound 3, half-maximal inhibitory concentration: 8320 nM
Beside the measured number, compound 3's estimate is 1.8-fold (0.26 log units) above it; the measured number falls inside the stated range.
By their numbers in this assay, from the lowest: compounds 3, 1 and 2 (each within the scatter of the next).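

Working notes on the urea aryl group: this is the first measured change on the amide-type nitrogen whose other neighbour is the carbonyl carbon, where in this assay 3-chloro-4-fluorophenyl in place of 3-(trifluoromethyl)phenyl gives a 2.0-fold lower number from compound 2 to compound 3 (0.29 log units; within the scatter). With the 4-(2-(dimethylamino)ethyl)-4H-1,2,4-triazol-3-yl group held constant, the two aryl groups cannot be put in order on this read-out, so this pair shows no measurable dependence on the exchange. No supporting measurement bears on this result.

Going by these compounds, it remains open whether 3-chloro-4-fluorophenyl would give a comparable number alongside the 1-methyl-1H-1,2,4-triazol-5-yl group of compound 1, as the step at the urea has been read only on the core of compound 2. On these data alone, it is also open whether a different group on the same nitrogen, such as an unsubstituted phenyl, a pyridine or a phenyl carrying a carboxylic acid or an amine, would move the number beyond the scatter.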